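The source may report more compounds than this note shows. Statements on the series, on what has been measured and on what is new or still open speak of the compounds shown alone.

In a functional assay on ECa-109 cells for inhibition, with ECa-109 cell line (Homo sapiens) as the target, read by sulforhodamine B assay (a higher number here means a weaker inhibitor, a lower number a stronger inhibitor), compound 1 `CCc1ccc(NC2=CC(=O)c3c(nc4n3[C@H]3OC[C@@H](O)[C@H]3OC4)C2=O)cc1` gives > 4000 nM, which is a limit of the assay and not a number. Compound 2 `CCc1ccc(NC2=CC(=O)c3nc4n(c3C2=O)[C@H]2OC[C@@H](O)[C@H]2OC4)cc1` differs from compound 1 only in how the shared core is joined. In this assay compound 2 gives 3080 nM. Compound 3 `O=C1C(N2CCC2)=CC(=O)c2c1nc1n2[C@H]2OC[C@@H](O)[C@H]2OC1` gives > 16000 nM, again a limit rather than a number. Compound 1 sits at the limit of > 4000 nM in this assay, at which 1 of the 3 values shown sits. Compound 3 sits at the limit of > 16000 nM in this assay, at which 1 of the 3 values shown sits. Among the measured compounds shown here, the single one-place step among the measured compounds, a step that the two limits leave unreadable from compound 1 to compound 3, therefore cannot be read in size.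

Compound 4 `CCOc1ccccc1NC1=CC(=O)c2c(nc3n2[C@H]2OC[C@@H](O)[C@H]2OC3)C1=O` carries 2-ethoxyphenyl in place of 4-ethylphenyl on an amine nitrogen. For the measured compounds named here, no measured step exchanges one substituted phenyl for another on that amine nitrogen, so the measured compounds offer no direct guide to this change, and both compound 1 and compound 2 are weak inhibitors in this assay. Compound 4 is expected to remain weak, with a step that the limit leaves unreadable from compound 1 to compound 4 that is more likely to fall within the scatter than beyond it. The estimate for compound 4 is 6000 nM, expected between 2000 nM and 20000 nM, with a fair chance that only a limit is reported.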

Compound 4, half-maximal inhibitory concentration: 4320 nM
Beside the measured number, compound 4's estimate is 1.4-fold (0.14 log units) above it; low and high end bracket the measured number.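

In this assay compound 4 gives 4320 nM. Compound 1 gives > 4000 nM, which is a limit and not a number, and the step between these two compounds cannot be read in size. The compounds shown leave open how far exchanging one substituted phenyl for another on the amine nitrogen changes inhibition.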